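Compound 4 in the growth-inhibition series: trimethoxyphenyl replacement

This account rests on a few compounds, and the source may have more. Where it says the series, first, only, none or still open, it means among the compounds named here.

Compound 1 `Cc1cc(O)c(C2=NN(c3ccc(S(N)(=O)=O)cc3)C(c3ccccc3O)C2)cc1Cl` gives 14600 nM in a functional assay on K562 cells (Homo sapiens) for antiproliferative activity, with a stated time of 48 h (on this read-out higher numbers stand for weaker inhibition of growth and lower numbers for stronger inhibition of growth), the lowest of the three numbers measured. Compound 2 `Cc1cc(O)c(C2=NN(c3ccc(S(N)(=O)=O)cc3)C(c3ccccc3Cl)C2)cc1Cl` gives 100000 nM and compound 3 `COc1ccc(C2CC(c3cc(Cl)c(C)cc3O)=NN2c2ccc(S(N)(=O)=O)cc2)cc1OC` gives 100000 nM; the steps of a 6.8-fold higher number from compound 1 to compound 2 (0.84 log units; beyond the scatter) and a 6.8-fold higher number from compound 1 to compound 3 (0.84 log units; beyond the scatter) both lie beyond the scatter, while no change at the digits printed from compound 2 to compound 3 (within the scatter) stays within it.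

Compound 4 `COc1ccc(C2CC(c3cc(Cl)c(C)cc3O)=NN2c2ccc(S(N)(=O)=O)cc2)c(OC)c1OC` differs from compound 1 by 2,3,4-trimethoxyphenyl in place of 2-hydroxyphenyl on a saturated ring carbon. The measured step that bears on this is a 6.8-fold higher number from compound 1 to compound 3 (0.84 log units; beyond the scatter), where a methoxy-bearing phenyl also took the place of 2-hydroxyphenyl on a saturated ring carbon. A step of comparable size in the same direction is therefore expected, a 6.2-fold higher number from compound 1 to compound 4 (0.79 log units; beyond the scatter). Compound 4 is estimated at 90000 nM in this assay, with a range of 30000 nM to 100000 nM.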

Compound 4, concentration for total growth inhibition: 30900 nM
Beside the measured number, compound 4's estimate is 2.9-fold (0.46 log units) above it; the measured number falls inside the stated range.
By their numbers in this assay, from the lowest: compound 1; then compound 4; then compounds 2 and 3 (each within the scatter of the next).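

In this assay, a further methoxy in place of hydrogen on an aromatic carbon of the phenyl group gives a 3.2-fold lower number from compound 3 to compound 4 (0.51 log units; beyond the scatter), so the outcome at this saturated ring carbon depends on the methoxy pattern and not merely on methoxy being present. The 2,3,4-trimethoxyphenyl group also improves on 2-chlorophenyl, with a 3.2-fold lower number from compound 2 to compound 4 (0.51 log units; beyond the scatter), although neither has the hydroxy group of compound 1. Compound 1 still gives the lowest number, but the replacement now costs less, with a 2.1-fold higher number from compound 1 to compound 4 (0.33 log units; beyond the scatter).

No available evidence accounts for these differences. Going by these compounds, whether an amine or a carboxylic acid on this phenyl ring would match or improve on 2-hydroxyphenyl remains open.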